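Swapping the Ring on Nitrogen in an Inactive Pair

A few compounds are considered here, and "the series" means these few. Any claim that something is new, unique, unknown or untested is made for them only; others in the source may bear on it.

Measured compounds:
- Compound 1, `Cc1c(CCSCCO[N+](=O)[O-])cc(-c2ccc(S(C)(=O)=O)cc2)n1-c1ccccc1`: > 10000 nM
- Compound 2, `Cc1c(CCSCCO[N+](=O)[O-])cc(-c2ccc(S(C)(=O)=O)cc2)n1-c1ccc(F)c(F)c1`: > 10000 nM
- Compound 3, `Cc1c(CCSCCO)cc(-c2ccc(S(C)(=O)=O)cc2)n1-c1ccccc1`: > 10000 nM

In an assay on J774 cells for inhibition of prostaglandin G/H synthase 1 (Mus musculus), read by immunoassay, with stated times of 15 min and 30 min (a higher number here means a weaker inhibitor, a lower number a stronger inhibitor), compound 3 gives > 10000 nM. That value is a limit of the assay, not a number. The same holds for compound 1, which in this assay gives > 10000 nM, again a limit. Compound 2 likewise gives > 10000 nM in this assay, also a limit. All three values therefore sit at the limit of > 10000 nM in this assay, at which 3 of the 3 values shown sit, and nothing separates them on the numbers shown.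

Compound 4, `Cc1c(CCSCCO)cc(-c2ccc(S(C)(=O)=O)cc2)n1-c1ccc(F)c(F)c1`, has not yet been measured in this assay. It differs from compound 3 in one place: 3,4-difluorophenyl in place of phenyl on an aromatic nitrogen. The same exchange was made once before, from compound 1 to compound 2, where the result was a step that the two limits leave unreadable from compound 1 to compound 2. The other change that links the measured compounds, a step that the two limits leave unreadable from compound 1 to compound 3, is equally unreadable, because the limit of > 10000 nM in this assay, at which 3 of the 3 values shown sit, hides both.

Since every measured neighbour rests at the limit and neither step could be read, no movement beyond the scatter is expected. The change is estimated to amount to a step that the limit leaves unreadable from compound 3 to compound 4. Compound 4 is therefore expected to give about 20000 nM in this assay, most likely again reported only as a limit, with a plausible range from 5000 nM to 100000 nM.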

Compound 4, half-maximal inhibitory concentration: > 10000 nM
Compound 4: a limit, no number; the forecaster's own chance of this, stated with the estimate: 85%; the middle value does not contradict the limit.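

In this assay compound 4 gives > 10000 nM, which is a limit of the assay, not a number. Its steps from compound 3 and from compound 2 cannot be read, because every value rests at the same limit: the limit of > 10000 nM in this assay, at which 4 of the 4 values shown sit.

The compounds shown leave open how strongly any of the four inhibits, and whether either exchange alters that strength at all.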